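Swapping the substituent beside the isopropoxy group

This account rests on a few compounds, and the source may have more. Where it says the series, first, only, none or still open, it means among the compounds named here.

Measured so far:
- compound 1 `Cc1cc(CCC(=O)O)ccc1-c1noc(-c2ccc(OC(C)C)c(C(F)(F)F)c2)n1`: 40 nM
- compound 2 `Cc1cc(CCC(=O)O)ccc1-c1noc(-c2ccc(OC(C)C)c(Cl)c2)n1`: 140 nM

Both compounds share one core and differ only in the group next to the isopropoxy group. In a functional assay on CHO cells for agonist activity at sphingosine 1-phosphate receptor 5 (Homo sapiens), read by GTPgammaS binding (on this read-out lower numbers stand for an effect already at smaller amounts and higher numbers for an effect only at larger amounts of compound), compound 1 gives 40 nM, and compound 2 gives 140 nM. For the measured compounds named here, the single measured step, a 3.5-fold higher number from compound 1 to compound 2 (0.54 log units; beyond the scatter), shows that exchanging trifluoromethyl for chloro raised the number by a modest but real amount. Among the two numbers known, compound 2 therefore stands at the top, with compound 1 the only neighbour.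

Compound 3 `Cc1cc(-c2nc(-c3ccc(CCC(=O)O)cc3C)no2)ccc1OC(C)C` is the next variation at the same site: methyl in place of chloro on an aromatic carbon. Going by the values given here, no measured step covers a methyl at this position, so the only guide is the step from compound 1 to compound 2, which bears on the same site and was modest in size. A change of similar scale is expected again, most likely toward a somewhat higher number, though a result within the scatter would not surprise. The expected step is a 1.8-fold higher number from compound 2 to compound 3 (0.25 log units; within the scatter). Compound 3 is therefore estimated at 250 nM in this assay, with a plausible range from 100 nM to 700 nM.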

Compound 3, half-maximal effective concentration: 210 nM
The estimate for compound 3 lay 1.2-fold (0.08 log units) above the measured number; the measured number falls inside the stated range.
By their numbers in this assay, from the lowest: compound 1; then compounds 2 and 3 (each within the scatter of the next).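

In this assay, methyl in place of chloro on the aromatic carbon ortho to the isopropoxy group gives a 1.5-fold higher number from compound 2 to compound 3 (0.18 log units; within the scatter), so this read-out does not tell these two groups apart at this position. Trifluoromethyl now stands apart from both of them, not only from chloro: methyl in its place gives a 5.3-fold higher number from compound 1 to compound 3 (0.72 log units; beyond the scatter), and compound 1 keeps the lowest number of the three, with both of its steps beyond the usual scatter. What sets trifluoromethyl apart from the other two groups remains unexplained, as no supporting measurement accompanies these numbers.

The compounds shown leave open what a plain hydrogen, a methoxy group or a nitrile would give at this position, and whether a larger fluorinated group such as pentafluoroethyl would match or lower the number seen with trifluoromethyl. They also leave open whether the gap between trifluoromethyl and the other two groups would persist if an ethoxy group took the place of the isopropoxy group.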